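A few compounds are considered here, and "the series" means these few. Any claim that something is new, unique, unknown or untested is made for them only; others in the source may bear on it.

Compound 3 `O=C(CCC1=CCN(Cc2cccc(Br)c2)C1=O)NO` gives 4620 nM in a functional assay on PC-3 cells (Homo sapiens) for inhibition, read by sulforhodamine B assay; a higher number here means a weaker inhibitor of growth, a lower number a stronger inhibitor of growth. Among the measured compounds shown here, on the numbers so far it stands level with compound 1 `Cc1cccc(CN2CC=C(CCC(=O)NO)C2=O)c1`, which gives 4620 nM in this assay; compound 2 `O=C(CCC1=CCN(Cc2ccc(F)cc2)C1=O)NO` gives 5310 nM, and its gap to compound 3 also lies within the scatter. Compound 4 `O=C(CCC1=CCN(Cc2cccc(Cl)c2)C1=O)NO` differs from compound 3 by chloro in place of bromo on an aromatic carbon. For the measured compounds named here, the only measured step that bears on a change at this aromatic carbon is no change at the digits printed from compound 1 to compound 3 (within the scatter), which left the number unchanged. Going by the values given here, no step swaps one halogen for another, so the expectation rests on that one step alone. The step of a 1.0-fold lower number from compound 3 to compound 4 (0.00 log units; within the scatter) is therefore expected to stay within the scatter. Compound 4 is estimated at 4600 nM, with a range from 2300 nM to 9200 nM.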

Compound 4, concentration for 50% growth inhibition: 4620 nM
Estimate against measurement, compound 4: 1.0-fold (0.00 log units) below; the range from low to high includes it.
By their numbers in this assay, from the lowest: compounds 1, 3, 4 and 2 (each within the scatter of the next).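

Among the compounds shown here, the halogen swap at this aromatic carbon now has its own reading in this assay: there is no change at the digits printed from compound 3 to compound 4 (within the scatter), which no earlier pair could show. Chloro in place of methyl gives no change at the digits printed from compound 1 to compound 4 (within the scatter), so methyl, bromo and chloro at this place cannot be told apart in this assay. No measurement shown accounts for this sameness. On these data alone, it remains open whether an amine or a carboxylic acid on this aromatic carbon would also leave the number where it stands.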